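This account rests on a few compounds, and the source may have more. Where it says the series, first, only, none or still open, it means among the compounds named here.

Series notes, cytotoxicity read-out.

Measured so far:
- compound 1 `CCOC(=O)c1ccc(NC(=O)CSc2snnc2-c2ccccc2)c(Br)c1`: >= 232000 nM
- compound 2 `O=C(CSc1snnc1-c1ccccc1)Nc1ccccc1Cl`: > 345000 nM
- compound 3 `O=C(CSc1snnc1-c1ccccc1)Nc1ccccc1Br`: > 307000 nM

All three readings come from an ADME assay on MT4 cells (Homo sapiens) for cytotoxicity; on this read-out lower numbers stand for higher toxicity in this test and higher numbers for lower toxicity in this test. The reading for compound 1, >= 232000 nM, is a limit of the assay and not a number. The reading for compound 2, > 345000 nM, is likewise a limit. Compound 3 also gives only a limit, > 307000 nM. Where compound 3 stands among the three is therefore not readable, as the two further values are limits as well.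

The two measured steps that end in compound 3 are unreadable for the same reason: a step that the two limits leave unreadable from compound 1 to compound 3 and a step that the two limits leave unreadable from compound 2 to compound 3. Both ends of each step sit at a limit (the limit of > 307000 nM in this assay, at which 1 of the 3 values shown sits, (the limit of > 345000 nM in this assay, at which 1 of the 3 values shown sits), (the limit of >= 232000 nM in this assay, at which 1 of the 3 values shown sits)).

The next change is 2,4-difluorophenyl in place of phenyl on an aromatic carbon, giving compound 4 `O=C(CSc1snnc1-c1ccc(F)cc1F)Nc1ccccc1Br`. Neither measured step touches this part of the molecule, and neither has a readable size, so no direction beyond the scatter can be drawn from them. Every measured compound sits at a limit in this assay. Compound 4 is expected to do the same. The step of an at least 1.0-fold lower number from compound 3 to compound 4 (0.01 log units; that floor lies within the scatter) is estimated as essentially none. Compound 4 is estimated at 300000 nM, range 100000 nM to 400000 nM, most likely reported again only as a limit.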

Compound 4, half-maximal cytotoxic concentration: 144000 nM
Compound 4: the middle estimate sits 2.1-fold (0.32 log units) above what was measured; low and high end bracket the measured number.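

In this assay, 2,4-difluorophenyl in place of phenyl on an aromatic carbon of the five-membered aromatic ring gives an at least 2.1-fold lower number from compound 3 to compound 4 (0.32 log units; beyond the scatter), so a change at this position can move the read-out beyond the scatter. The earlier compounds shown here could not show this: their steps cannot be read, and neither step touches this position. Compound 4 is also the first compound here to give a number rather than a limit, yet the size of the step remains a floor only, because compound 3 gives a limit and not a number: the limit of > 307000 nM in this assay, at which 1 of the 4 values shown sits.

On these data alone, whether both fluoro groups are needed for this step stays open, as does the outcome with a phenyl bearing a single fluoro, a methoxy or a carboxylic acid at this position. Also open, as far as these compounds go, is whether the same exchange would lower the number on the chloro-bearing anilide of compound 2 or the ethoxycarbonyl-bearing anilide of compound 1, and the values shown give no cause for the step.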